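The source may report more compounds than this note shows. Statements on the series, on what has been measured and on what is new or still open speak of the compounds shown alone.

Two compounds share one core and differ only in the group on the nitrogen attached to it. Among the measured compounds shown here, compound 1 `CCS(=O)(=O)Nc1cc(-c2ccc3ncnc(Nc4cccc(F)c4)c3c2)cnc1OC` carries a 3-fluorophenyl there; in a functional assay on BT-549 cells (Homo sapiens) for cytotoxicity, read by sulforhodamine B assay, with a stated time of 72 h (a lower number here means a stronger inhibitor, a higher number a weaker inhibitor), compound 1 gives 2760 nM, the highest of the two numbers measured so far. Compound 2 `CCS(=O)(=O)Nc1cc(-c2ccc3ncnc(Nc4ccc(OC)c(OC)c4)c3c2)cnc1OC` carries a 3,4-dimethoxyphenyl instead, and in this assay compound 2 gives 2590 nM. For the measured compounds named here, the one step available, a 1.1-fold lower number from compound 1 to compound 2 (0.03 log units; within the scatter), shows that swapping the group on that ring left the number essentially where it was.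

Compound 3 `CCS(=O)(=O)Nc1cc(-c2ccc3ncnc(Nc4cccc(C(=O)OC)c4)c3c2)cnc1OC` has not yet been measured. It differs from compound 1 in one place: methoxycarbonyl in place of fluoro on an aromatic carbon. Going by the values given here, no measured step changes fluoro into methoxycarbonyl, so the only guide is that earlier step, which altered the same ring and stayed within the scatter. On that basis a step of a 1.0-fold higher number from compound 1 to compound 3 (0.01 log units; within the scatter) is expected, that is, nothing beyond the scatter. Compound 3 is therefore estimated at 2800 nM in this assay, with a range from 1200 nM to 6500 nM.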

Compound 3, half-maximal inhibitory concentration: 1080 nM
Estimate against measurement, compound 3: 2.6-fold (0.41 log units) above, and the stated range ends above it.
By their numbers in this assay, from the lowest: compound 3; then compounds 2 and 1 (each within the scatter of the next).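

Among the compounds shown here, this is the first change on this ring that moves the number beyond the scatter in this assay: methoxycarbonyl in place of fluoro, on an aromatic carbon meta to a large group, gives a 2.6-fold lower number from compound 1 to compound 3 (0.41 log units; beyond the scatter) and counts as a modest step. The comparison with the other measured ring points the same way, with a 2.4-fold lower number from compound 2 to compound 3 (0.38 log units; beyond the scatter), so the group on the nitrogen can matter here, and among these three compounds the 3-(methoxycarbonyl)phenyl group stands apart, while the 3-fluorophenyl and 3,4-dimethoxyphenyl groups remain within the scatter of each other. No measurement offered here accounts for this difference, so it stands as an observation only.

On these data alone, it remains open whether the lower number depends on the whole methoxycarbonyl group or on only part of it, a question that a carboxylic acid, a primary amide or a nitrile on the same aromatic carbon could help to answer. A longer chain on the oxygen, as in ethoxycarbonyl, would show whether the step survives when the group grows.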